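The source may hold more compounds than are shown below. What is called first, only, known or untested is meant among the compounds shown, and "the series" means these compounds.

Within the data shown here, only two compounds sharing one core have been measured so far in an ADME assay on microsomes from liver (Homo sapiens) for metabolic stability; on this read-out higher numbers stand for a longer-lived compound and lower numbers for a shorter-lived compound. Compound 1 (`COc1cc(OCc2cccc(-c3ccc(C(F)(F)F)cn3)c2)c2cc(-c3cn4nc(OC)sc4n3)oc2c1`) gives 0.733 h, and compound 2 (`COc1cc(OCc2cccc(-c3ccc(C#N)cn3)c2)c2cc(-c3cn4nc(OC)sc4n3)oc2c1`) gives 1.57 h, the higher of the two numbers.

Compound 3 (`COc1cc(OCc2cccc(-c3cnc(OC)nc3)c2)c2cc(-c3cn4nc(OC)sc4n3)oc2c1`) keeps that core but carries 2-methoxypyrimidin-5-yl in place of 5-cyanopyridin-2-yl on an aromatic carbon, meta to a large group: 2-methoxypyrimidin-5-yl in place of 5-cyanopyridin-2-yl on an aromatic carbon.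

Just one measured step bears on this change, and it is only a loose guide. That step, a 2.1-fold higher number from compound 1 to compound 2 (0.33 log units; beyond the scatter), was modest and exchanged cyano for trifluoromethyl, whereas the new change replaces the whole 5-cyanopyridin-2-yl group. Among the measured compounds shown here, no measured compound carries 2-methoxypyrimidin-5-yl, so the direction remains uncertain. Since compound 2 holds the higher number at 1.57 h, a modest fall is the more cautious expectation, similar in size to the earlier step. The expected change is a 1.6-fold lower number from compound 2 to compound 3 (0.20 log units; within the scatter). For compound 3 the estimated half-life in this assay is 1 h, with an expected range of 0.4 h to 2.4 h.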

Compound 3, half-life: 0.6 h
For compound 3 the middle estimate is 1.7-fold (0.22 log units) above the measured one; low and high end bracket the measured number.
By their numbers in this assay, from the lowest: compounds 3 and 1 (each within the scatter of the next); then compound 2.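

In this assay, this position, on an aromatic carbon of a six-membered aromatic ring of carbon only, now shows a response to replacing the whole aromatic group and not just its substituent, with a 2.6-fold lower number from compound 2 to compound 3 (0.42 log units; beyond the scatter) when 2-methoxypyrimidin-5-yl takes the place of 5-cyanopyridin-2-yl. The other new step, a 1.2-fold lower number from compound 1 to compound 3 (0.09 log units; within the scatter), means that 2-methoxypyrimidin-5-yl and 5-(trifluoromethyl)pyridin-2-yl cannot be told apart on this read-out. Of the three groups, only 5-cyanopyridin-2-yl stands clear of the other two, and nothing measured here explains why.

Compound 3 alters the ring and its substituent in one move, which leaves open whether the nitrile or the pyridine ring matters more for the half-life of compound 2. Also open, on these data alone, is how the half-life would respond to a different kind of group on the pyridine ring, such as an amine or a carboxylic acid in place of the nitrile.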